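The source may report more compounds than this note shows. Statements on the series, on what has been measured and on what is new or still open speak of the compounds shown alone.

In a functional assay on MGC-803 cells (Homo sapiens) for inhibition, read by MTT assay, with a stated time of 48 h (on this read-out lower numbers stand for stronger inhibition and higher numbers for weaker inhibition), the measured compounds give these values
compound 1 `COc1ccc(CNc2cc(OC)c(OC)c(OC)c2)cc1[N+](=O)[O-]` gives 19400 nM
compound 2 `COC(=O)c1cc(CNc2cc(OC)c(OC)c(OC)c2)ccc1OC` gives 49600 nM
compound 3 `CCC/C=C/C(=O)N(Cc1ccc(OC)c(O)c1)c1cc(OC)c(OC)c(OC)c1` gives 70 nM

Compound 2 has the highest number of the three, with compound 1 the nearest to it. Among the compounds with values here, compound 3 lies far lower but differs from both in more than one place, and no single step links it to them. The next compound is compound 4 `COc1ccc(CNc2cc(OC)c(OC)c(OC)c2)cc1`, which has hydrogen in place of methoxycarbonyl on an aromatic carbon, ortho to a methoxy group (hydrogen in place of methoxycarbonyl on an aromatic carbon). Within the data shown here, the only measured step at this carbon is a 2.6-fold higher number from compound 1 to compound 2 (0.41 log units; beyond the scatter) with methoxycarbonyl in place of nitro. That step is modest. Among the measured compounds shown here, no measured compound has hydrogen at this carbon, so the guide is indirect. A similarly modest step in this assay is therefore expected, though a step within the scatter remains possible. The expected step is a 2.5-fold lower number from compound 2 to compound 4 (0.39 log units; beyond the scatter) in the direction of a lower number. For compound 4 the estimated value is 20000 nM with 6000 nM to 60000 nM as the expected range.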

Compound 4, half-maximal inhibitory concentration: 11400 nM
The estimate for compound 4 lay 1.8-fold (0.24 log units) above the measured number, within the range that was stated.
By their numbers in this assay, from the lowest: compound 3; then compounds 4 and 1 (each within the scatter of the next); then compound 2.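

In this assay, within the data shown here, the new compound gives the first reading with hydrogen at this carbon: a 4.4-fold lower number from compound 2 to compound 4 (0.64 log units; beyond the scatter), so replacing methoxycarbonyl with hydrogen shifts the number beyond the scatter. Hydrogen and nitro, by contrast, cannot be told apart here, with a 1.7-fold lower number from compound 1 to compound 4 (0.23 log units; within the scatter), which leaves methoxycarbonyl as the only one of the three groups at this carbon that stands apart from the other two. No evidence is at hand on what lies behind these steps.

From the compounds shown here alone, whether an amine or a carboxylic acid at this carbon would stay level with hydrogen and nitro or sit with methoxycarbonyl remains open. Compound 3 differs from these compounds in more than one place, so the share of this carbon in its far lower number cannot be read.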